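A few compounds are considered here, and "the series" means these few. Any claim that something is new, unique, unknown or untested is made for them only; others in the source may bear on it.

Measured in a functional assay on MX1 cells (Homo sapiens) for inhibition, read by MTT assay, with a stated time of 120 h; a lower number here means a stronger inhibitor, a higher number a weaker inhibitor:
- compound 1 `CNC(=O)/C=C/c1ccc(NC(=O)Nc2ccc(Cl)c(C(F)(F)F)c2)cc1`: 13800 nM
- compound 2 `CNC(=O)c1cccc(-c2ccc(NC(=O)Nc3ccc(Cl)c(C(F)(F)F)c3)cc2)c1`: > 50000 nM (a limit, not a number)

On these data alone, compound 2 stands at the limit of > 50000 nM in this assay, at which 1 of the 2 values shown sits, so its true position is unknown. The change to compound 3 `O=C(CCc1ccc(NC(=O)Nc2ccc(Cl)c(C(F)(F)F)c2)cc1)NC1CCC1` falls on an aromatic carbon of the shared core, para to a large group, where 2-(cyclobutylcarbamoyl)ethyl takes the place of 3-(methylcarbamoyl)phenyl: 2-(cyclobutylcarbamoyl)ethyl in place of 3-(methylcarbamoyl)phenyl on an aromatic carbon.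

Within the data shown here, one measured step bears on this change. It is an at least 3.6-fold higher number from compound 1 to compound 2 (0.55 log units; beyond the scatter), and it brought in the same 3-(methylcarbamoyl)phenyl in place of 2-(methylcarbamoyl)ethenyl. With that group leaving again, a move of similar size in the opposite direction is expected in this assay, towards the level of compound 1 at 13800 nM. Among the measured compounds shown here, no measured step covers the cyclobutyl group or the ethyl chain, so the expectation stays loose, and another limit remains possible.

The estimated step is an at least 3.1-fold lower number from compound 2 to compound 3 (0.49 log units; beyond the scatter).

For compound 3 the expected value is 16000 nM, with an estimated range of 5000 nM to 50000 nM.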

Compound 3, half-maximal inhibitory concentration: 24000 nM
Estimate against measurement, compound 3: 1.5-fold (0.18 log units) below; the range from low to high includes it.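

In this assay, among these compounds, the change from 3-(methylcarbamoyl)phenyl to 2-(cyclobutylcarbamoyl)ethyl gives an at least 2.0-fold lower number from compound 2 to compound 3 (0.31 log units; beyond the scatter), the first reading of a group leaving this position rather than entering it, and it shows that the loss seen with the aromatic group is not a fixed feature of the shared core. On these data alone, the true size of this step stays unknown, and compound 2 is a limit, not a number: the limit of > 50000 nM in this assay, at which 1 of the 3 values shown sits. Set against the other chain, 2-(cyclobutylcarbamoyl)ethyl in place of 2-(methylcarbamoyl)ethenyl gives a 1.7-fold higher number from compound 1 to compound 3 (0.24 log units; within the scatter), which leaves compound 1 and compound 3 indistinguishable in this assay even though the groups differ in both the chain and the amide substituent.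

The compounds shown do not separate the ethenyl-to-ethyl change from the methyl-to-cyclobutyl change, so the contribution of each, and whether the two offset one another, remains unknown. As far as these compounds go, it also remains open whether a longer chain, a carboxylic acid or an amide bearing a cyclohexyl group at this position would give a number clearly lower than those of compound 1 and compound 3.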